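Hydrazinyl for Methylsulfanyl on a Thiophene-Bearing Pyrimidinone Core

This account rests on a few compounds, and the source may have more. Where it says the series, first, only, none or still open, it means among the compounds named here.

Measured so far:
compound 1, `CSc1nc(-c2cccs2)c(C#N)c(=O)n1C`: 71 ug/mL
compound 2, `CSc1nc(-c2ccccc2O)c(C#N)c(=O)n1C`: 52 ug/mL
compound 3, `Cn1c(NN)nc(-c2ccccc2O)c(C#N)c1=O`: 38 ug/mL

The three measured compounds were tested in a functional assay, with a stated time of 20 min; on this read-out higher numbers stand for weaker inhibition and lower numbers for stronger inhibition. In this assay compound 1 gives 71 ug/mL, compound 2 gives 52 ug/mL and compound 3 gives 38 ug/mL. How the core of compound 1 differs from that of compound 2 is not broken down here. Compound 2 and compound 3 differ in one place: aminoamino in place of methylsulfanyl on an aromatic carbon. This produced a 1.4-fold lower number from compound 2 to compound 3 (0.14 log units; within the scatter).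

The unmeasured compound 4, `Cn1c(NN)nc(-c2cccs2)c(C#N)c1=O`, differs from compound 1 by the same kind of change: aminoamino in place of methylsulfanyl on an aromatic carbon. Around the place the two differ only in that compound 1 carries a thiophen-2-yl group where compound 2 carries a group of 7 heavy atoms. Because the step of a 1.4-fold lower number from compound 2 to compound 3 (0.14 log units; within the scatter) stayed within the scatter, compound 4 is expected to show a step of similar size, a 1.4-fold lower number from compound 1 to compound 4 (0.14 log units; within the scatter). Compound 4 is therefore estimated at 52 ug/mL, with a range from 30 ug/mL to 90 ug/mL.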

Compound 4, half-maximal inhibitory concentration: 61 ug/mL
The estimate for compound 4 lay 1.2-fold (0.07 log units) below the measured number; the range from low to high includes it.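

In this assay, placing aminoamino in place of methylsulfanyl on the core of compound 1 gave a 1.2-fold lower number from compound 1 to compound 4 (0.07 log units; within the scatter). Set beside the earlier case, the change read the same on both cores: the same change on two cores in this assay, a 1.4-fold lower number (0.14 log units; within the scatter) from compound 2 to compound 3 and a 1.2-fold lower number (0.07 log units; within the scatter) from compound 1 to compound 4, 1.2-fold (0.07 log units) apart, within the scatter of two such steps. This shows that the step stayed within the scatter on these two cores, but it does not show that the change strengthens inhibition on either, and two cores cannot speak for the whole series.

The compounds shown leave open how other groups on this aromatic carbon would read, such as a primary amine, a methoxy group or a longer thioether chain. They also leave open whether the step stays this small on cores with other groups in place of thiophen-2-yl.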